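The source may hold more compounds than are shown below. What is called first, only, known or untested is meant among the compounds shown, and "the series" means these compounds.

Compound 1 `COc1ccc(C(=O)c2cc(OC)c(OC)c(OC)c2)c(NC(=O)CO)c1`: 230 nM
Compound 2 `C=C(c1cc(OC)c(OC)c(OC)c1)c1ccc(OC)c(O)c1NC(C)=O`: 270 nM

Both compounds were tested in a functional assay on MCF7 cells (Homo sapiens) for antiproliferative activity, read by MTT assay, with a stated time of 48 h (on this read-out higher numbers stand for weaker inhibition and lower numbers for stronger inhibition), and their values lie within the usual scatter of each other. Among the compounds with values here, compound 2, at 270 nM, therefore stands level with compound 1 on the numbers so far. Compound 3 `C=C(c1cc(OC)c(OC)c(OC)c1)c1ccc(OC)c(O)c1NC(=O)CO` departs from compound 2 in one place: hydroxy in place of hydrogen on a saturated chain carbon bound to a carbonyl carbon. This is hydroxy in place of hydrogen on a saturated chain carbon bound to a carbonyl carbon, which turns acetamido into ((hydroxymethyl)carbonyl)amino.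

Within the data shown here, no measured pair shows this change on its own, so its size in this assay cannot be read directly. The only indirect hint comes from compound 1, which carries ((hydroxymethyl)carbonyl)amino on a core of its own and gives 230 nM. That single value offers no sign of a large gain or loss, though it cannot separate the group from the difference in core. The step of a 1.1-fold lower number from compound 2 to compound 3 (0.05 log units; within the scatter) is therefore expected to stay within the scatter, with no favoured direction. For compound 3 the estimated value is 240 nM, with an expected range from 70 nM to 800 nM.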

Compound 3, half-maximal inhibitory concentration: 50 nM
Estimate against measurement, compound 3: 4.8-fold (0.68 log units) above; the measured number lies below the stated range.
By their numbers in this assay, from the lowest: compound 3; then compounds 1 and 2 (each within the scatter of the next).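

In this assay, turning acetamido into ((hydroxymethyl)carbonyl)amino gives a 5.4-fold lower number from compound 2 to compound 3 (0.73 log units; beyond the scatter), the first measured effect of this change on its own. This shows that the position, a saturated chain carbon bound to a carbonyl carbon, is not indifferent to what it carries: hydroxy in place of hydrogen moves the number towards stronger inhibition, which compound 1, with the same group on a core of its own and no acetamido partner, could not show. Nothing measured here bears on the reason for this step.

As far as these compounds go, it remains open whether the step is specific to hydroxy, or whether a methoxy group, an amine or a fluorine on the same carbon, or a longer chain such as hydroxyethyl, would give a similar number. A single pair also leaves open whether the step would carry over to the core of compound 1, where the matching acetamido compound is not among those shown.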